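From 2-methylphenyl to 3-methylphenyl in compound 4

The source may report more compounds than this note shows. Statements on the series, on what has been measured and on what is new or still open speak of the compounds shown alone.

Values in an ADME assay on HUVEC cells (Homo sapiens) for cytotoxicity, read by MTT assay, with a stated time of 24 h; a higher number here means that more compound is tolerated, a lower number that less compound is tolerated:
- compound 1 `Fc1ccc(/C=C/c2nnc(-c3ccc4c(c3)OCCO4)o2)cc1` gives 325000 nM
- compound 2 `Fc1cccc(/C=C/c2nnc(-c3ccc4c(c3)OCCO4)o2)c1` gives 295000 nM
- compound 3 `Cc1ccccc1/C=C/c1nnc(-c2ccc3c(c2)OCCO3)o1` gives 356000 nM

Compound 3 stands level with the other two, as its steps show (a 1.1-fold higher number from compound 1 to compound 3 (0.04 log units; within the scatter) and a 1.2-fold higher number from compound 2 to compound 3 (0.08 log units; within the scatter)). Compound 4 `Cc1cccc(/C=C/c2nnc(-c3ccc4c(c3)OCCO4)o2)c1` carries 3-methylphenyl in place of 2-methylphenyl on a double-bonded chain carbon bound to a double-bonded chain carbon. Within the data shown here, no pair of methylphenyl compounds has been measured yet. Among the measured compounds shown here, the closest precedent is the fluorophenyl pair (a 1.1-fold lower number from compound 1 to compound 2 (0.04 log units; within the scatter)), and all three measured steps are similarly small. No step beyond the scatter is expected (a 1.1-fold lower number from compound 3 to compound 4 (0.03 log units; within the scatter)). Compound 4 is expected at 330000 nM (estimated range 220000 nM to 480000 nM).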

Compound 4, half-maximal cytotoxic concentration: 201000 nM
The estimate for compound 4 lay 1.6-fold (0.22 log units) above the measured number; the whole stated range lies above it.
By their numbers in this assay, from the lowest: compounds 4, 2, 1 and 3 (each within the scatter of the next).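

In this assay, the series now holds its first pair of methylphenyl compounds, and 3-methylphenyl in place of 2-methylphenyl gives a 1.8-fold lower number from compound 3 to compound 4 (0.25 log units; within the scatter). Methyl in place of fluoro on an aromatic carbon gives a 1.5-fold lower number from compound 2 to compound 4 (0.17 log units; within the scatter), and 3-methylphenyl in place of 4-fluorophenyl gives a 1.6-fold lower number from compound 1 to compound 4 (0.21 log units; within the scatter). Thus neither change of this group takes the number beyond the scatter in these compounds.

Nothing at hand bears on what lies behind these steps. Going by these compounds, whether an amine or a carboxylic acid on this phenyl ring would leave the same narrow band remains open.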